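This account rests on a few compounds, and the source may have more. Where it says the series, first, only, none or still open, it means among the compounds named here.

Compound 1 `CCCCCCOc1ccc(C(O)C2OC(=O)c3c(OC)cc(OC)cc32)cc1` gives > 40000 nM (a limit)
Compound 2 `COCCOc1ccc(C(O)C2OC(=O)c3c(OC)cc(OC)cc32)cc1` gives > 40000 nM (a limit)

In an ADME assay on RAW264.7 cells (Mus musculus) for cytotoxicity, read by MTT assay, with a stated time of 24 h, in the presence of a further agent that is not named here (a higher number here means a weaker inhibitor, a lower number a stronger inhibitor), compound 2 stands at > 40000 nM as a limit and not a number. Among the compounds with values here, the one measured step is a step that the two limits leave unreadable from compound 1 to compound 2 and offers no size to carry forward. Compound 3 `CCOCCOc1ccc(C(O)C2OC(=O)c3c(OC)cc(OC)cc32)cc1` differs from compound 2 by methyl in place of hydrogen on a saturated chain carbon bound to an oxygen on a saturated carbon and so turns methoxy to ethoxy. With no readable size to go on, no change beyond the usual scatter is expected, and the estimated step is a step that the limit leaves unreadable from compound 2 to compound 3 in all. For compound 3 the estimated value is 45000 nM with an expected range from 30000 nM to 80000 nM in this assay and a report of only a limit is likely.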

Compound 3, half-maximal inhibitory concentration: > 40000 nM
Compound 3: a limit, no number; the forecaster's own chance of this, stated with the estimate: 90%; the middle value is on the limit's open side.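

Compound 3 also gives only a limit, so its steps from compound 1 and compound 2 cannot be read: the limit of > 40000 nM in this assay, at which 3 of the 3 values shown sit.

On these data alone, whether the differing chain affects cytotoxicity at all remains open for compound 1, compound 2 and compound 3.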